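A few compounds are considered here, and "the series" means these few. Any claim that something is new, unique, unknown or untested is made for them only; others in the source may bear on it.

Measured so far:
- compound 1, `NCCCNc1c(C(=O)NCc2ccc(F)cc2)nc(Br)c2cccnc12`: 5000 nM
- compound 2, `COc1ccc(CNC(=O)c2nc(Br)c3cccnc3c2N[C@H]2CC[C@H](N)CC2)cc1`: 5000 nM

Both compounds share a core and were tested in a functional assay on MDA-MB-435 cells (Homo sapiens) for cytotoxicity, read by MTT assay, with a stated time of 72 h; on this read-out higher numbers stand for weaker inhibition and lower numbers for stronger inhibition. On that read-out compound 1 gives 5000 nM, and compound 2 gives 5000 nM; the two values are within the scatter of each other, so nothing separates them at the digits shown. Among the compounds with values here, no step between measured compounds that differ in one place is available, so the direction of any single change must be judged from the structural difference alone.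

Compound 3, `COC(=O)CNc1c(C(=O)NCc2ccc(F)cc2)nc(Br)c2cccnc12`, has not yet been measured in this assay. It differs from compound 1 by one replacement: methoxycarbonyl in place of 2-aminoethyl on a saturated chain carbon bound to a nitrogen on an aromatic ring. The change exchanges 3-aminopropyl for (methoxycarbonyl)methyl on the nitrogen attached to the core, trading a donor-bearing chain for one carrying only acceptors. Within the data shown here, with no measured pair to anchor this change, a step of modest size is expected, if any, and it is expected to be either nil within the scatter or toward weaker inhibition rather than stronger; the expected step is a 1.2-fold higher number from compound 1 to compound 3 (0.08 log units; within the scatter). Compound 3 is therefore estimated at 6000 nM, in the range 2000 nM to 20000 nM.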

Compound 3, half-maximal inhibitory concentration: 10000 nM
Compound 3: middle estimate off by 1.7-fold (0.22 log units), on the low side; the measured number falls inside the stated range.
By their numbers in this assay, from the lowest: compounds 1, 2 and 3 (each within the scatter of the next).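

In this assay, the replacement of 2-aminoethyl by methoxycarbonyl on a saturated chain carbon bound to a nitrogen on an aromatic ring gives a 2.0-fold higher number from compound 1 to compound 3 (0.30 log units; within the scatter), the first single-place comparison available for this series. For this pair, a group with 1 hydrogen-bond donor and 1 hydrogen-bond acceptor gives way to one with 0 hydrogen-bond donors and 2 hydrogen-bond acceptors, and the amine on the chain is lost, yet the two numbers stay within the scatter of each other, so the read-out does not separate the 3-aminopropyl and (methoxycarbonyl)methyl compounds. No measurement is at hand that would bear on how this result arises.

What the compounds shown leave open is whether another group at this place, such as a carboxylic acid, a primary amide or a piperidine, would move the number beyond the scatter. On these data alone, it also remains open whether a longer chain carrying the methoxycarbonyl group would give a number that can be told apart from that of compound 3.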